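The source may hold more compounds than are shown below. What is called first, only, known or untested is meant among the compounds shown, and "the series" means these compounds.

Within the data shown here, the series so far holds two measured compounds. In a functional assay on MCF7 cells (Homo sapiens) for inhibition, read by CCK-8 assay, with a stated time of 72 h (on this read-out higher numbers stand for weaker inhibition and lower numbers for stronger inhibition), compound 1 (`O=C(/C=C/c1cccnc1)NCCCCCc1cccc(S(=O)(=O)Nc2ccccc2)c1`) gives 12.5 nM and compound 2 (`Cc1ccc(C)c(NS(=O)(=O)c2cccc(CCCCCCNC(=O)/C=C/c3cccnc3)c2)c1`) gives 0.6 nM as the lower of the two numbers, with the gap between them beyond the usual scatter. The two compounds differ in more than one place, so that gap cannot be assigned to any single change.

Compound 3 (`O=C(/C=C/c1cccnc1)NCCCCCCc1cccc(S(=O)(=O)Nc2ccc(F)c(Cl)c2)c1`) carries 3-chloro-4-fluorophenyl in place of 2,5-dimethylphenyl on a sulfonamide nitrogen and has not yet been measured. Among the measured compounds shown here, no measured pair isolates a change at this place, so any step in this assay remains uncertain. Compound 2 at 0.6 nM is the lowest number seen, and a moderate move toward a higher number, meaning weaker inhibition, is expected from that starting point. The expected step is a 3.3-fold higher number from compound 2 to compound 3 (0.52 log units; beyond the scatter) on this estimate, though a result within the scatter of compound 2 would not be surprising. For compound 3 the estimated value is 2 nM within an expected range of 0.4 nM to 10 nM in this assay.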

Compound 3, half-maximal inhibitory concentration: 6.3 nM
Compound 3: the middle estimate sits 3.2-fold (0.50 log units) below what was measured, within the range that was stated.
By their numbers in this assay, from the lowest: compound 2; then compounds 3 and 1 (each within the scatter of the next).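

In this assay, among these compounds, the sulfonamide nitrogen is the first place where a single change can be read: 3-chloro-4-fluorophenyl in place of 2,5-dimethylphenyl gives an 11-fold higher number from compound 2 to compound 3 (1.02 log units; beyond the scatter), a large step. This position therefore responds strongly to the substituents on the aromatic ring, even though the two groups have the same heavy-atom count, a six-membered aromatic ring of carbon only, and no hydrogen-bond donors or acceptors. No measurement available here bears on the origin of this step, so it stands as an observation only.

The change replaces both methyl groups and introduces both halogens in one step, so the shown compounds do not separate the contribution of either methyl group, the chlorine or the fluorine, and compound 1 differs from compound 2 and compound 3 in more than one place, so it cannot settle this. Still open, as far as these compounds go, is how this position would respond to a single methyl or single chlorine on the ring, or to an amine or a carboxylic acid there, with the rest of compound 2 held constant.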